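Methyl to methoxy on the pendant aryl ring, two cores

A few compounds are considered here, and "the series" means these few. Any claim that something is new, unique, unknown or untested is made for them only; others in the source may bear on it.

Compound 1 `COC(=O)[C@H](CCSC)NC(=O)c1ccc(OC[C@@H]2COc3ccccc3O2)cc1-c1ccccc1C` and compound 2 `COC(=O)[C@H](CCSC)NC(=O)c1ccc(OC[C@@H]2COc3ccccc3O2)cc1-c1ccccc1OC` share one core; in a functional assay (HSMC cells, Homo sapiens) for antiproliferative activity, with a stated time of 72 h (a higher number here means a weaker inhibitor, a lower number a stronger inhibitor), compound 1 gives 193000 nM and compound 2 gives 204000 nM. The change between them, (methoxy in place of methyl on an aromatic carbon), made a step of a 1.1-fold higher number from compound 1 to compound 2 (0.02 log units; within the scatter).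

Compound 3 `COC(=O)CNC(=O)c1ccc(OC[C@H]2COc3ccccc3O2)cc1-c1ccccc1C` carries a different core; the difference between the two cores is not broken down here. In this assay compound 3 gives 27000 nM, the lowest of the three numbers, with compound 1 and compound 2 both well beyond the scatter from it.

Compound 4 `COC(=O)CNC(=O)c1ccc(OC[C@H]2COc3ccccc3O2)cc1-c1ccccc1OC` is compound 3 with the same change, (methoxy in place of methyl on an aromatic carbon), and the place is described in the same words for both pairs. Compound 4 has not yet been measured in this assay.

The step from compound 3 to compound 4 is expected to be about a 1.1-fold higher number from compound 3 to compound 4 (0.05 log units; within the scatter), in line with the step of a 1.1-fold higher number from compound 1 to compound 2 (0.02 log units; within the scatter) seen on the other core. On that basis compound 4 is estimated at 30000 nM, within roughly 12000 nM to 75000 nM.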

Compound 4, half-maximal inhibitory concentration: 71000 nM
Compound 4: the middle estimate sits 2.4-fold (0.37 log units) below what was measured; the measured number falls inside the stated range.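

On the core of compound 3, methoxy in place of methyl on the pendant aryl ring gives a modest step in this assay, a 2.6-fold higher number from compound 3 to compound 4 (0.42 log units; beyond the scatter). The two steps on the two cores do not differ by more than the scatter, so as far as this one comparison can tell, the change carries from one core to the other: the same change on two cores in this assay, a 1.1-fold higher number (0.02 log units; within the scatter) from compound 1 to compound 2 and a 2.6-fold higher number (0.42 log units; beyond the scatter) from compound 3 to compound 4, 2.5-fold (0.40 log units) apart, within the scatter of two such steps

Among these compounds, with only two matched pairs, this does not show that the step would hold on further cores, nor does it show which feature of either core, if any, sets the size of the step.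

Left open is how other groups at the same place on the pendant aryl ring would compare with methyl and methoxy, for example fluorine, hydroxyl or ethyl. Also open, going by these compounds, is whether the same step would appear with a carboxylic acid in place of the methyl ester.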